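Compound 4 and the metabolic stability limit

This account rests on a few compounds, and the source may have more. Where it says the series, first, only, none or still open, it means among the compounds named here.

Values measured in an in vitro ADME assay on microsomes from liver (Homo sapiens) for metabolic stability, tested at 5 uM; a lower number here means that the compound disappears faster, a higher number that the compound lasts longer:
- Compound 1 `CC(C)CCn1nc(CC(C)C)c(O)c(C2=NS(=O)(=O)c3cc(NS(C)(=O)=O)ccc3N2)c1=O`: 0.123 h
- Compound 2 `CS(=O)(=O)Nc1ccc2c(c1)S(=O)(=O)N=C(c1c(O)c(-c3cccs3)nn(CCC3CC3)c1=O)N2`: > 1 h, a limit
- Compound 3 `CCCC(C)n1nc(-c2cccs2)c(O)c(C2=NS(=O)(=O)c3cc(NS(C)(=O)=O)ccc3N2)c1=O`: > 1 h, a limit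

Compound 3 stands at a limit, > 1 h. Two compounds share it: the limit of > 1 h in this assay, at which 2 of the 3 values shown sit. Compound 4 `CS(=O)(=O)Nc1ccc2c(c1)S(=O)(=O)N=C(c1c(O)c(-c3cccs3)nn(CCC3CCC3)c1=O)N2` carries 2-cyclobutylethyl in place of 1-methylbutyl on an aromatic nitrogen. Within the data shown here, the only measured step at this place is a step that the two limits leave unreadable from compound 2 to compound 3, so it offers no size to carry over. No step beyond the scatter is therefore expected in this assay, in either direction. The expected move is a step that the limit leaves unreadable from compound 3 to compound 4, and this is only an estimate. Compound 4 is expected at 1.2 h, with an estimated range of 0.4 h to 3.5 h.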

Compound 4, half-life: > 1 h
Compound 4: only a limit was reported; the forecaster's own chance of this, stated with the estimate: 60%; the middle value is on the limit's open side.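

Compound 2, compound 3 and compound 4 all stand at a limit, and the steps from compound 2 and from compound 3 to compound 4 cannot be read. Going by these compounds, how far their half-lives lie past that limit remains open, and with it any order among the three.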